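Methyl to fluoro on two furan- and thiophene-type cores

A few compounds are considered here, and "the series" means these few. Any claim that something is new, unique, unknown or untested is made for them only; others in the source may bear on it.

Compound 1 `C/C(=C\c1ccc(-c2ccc(C)cc2)o1)C(N)=O` and compound 2 `C/C(=C\c1ccc(-c2ccc(F)cc2)o1)C(N)=O` share one core, and in a functional assay on HO8910 cells (Homo sapiens) for cytotoxicity, read by CCK-8 assay, with a stated time of 24 h (on this read-out higher numbers stand for weaker inhibition and lower numbers for stronger inhibition), compound 1 gives 1660 nM while compound 2 gives 990 nM. The change between them is fluoro in place of methyl on an aromatic carbon, and it made a 1.7-fold lower number from compound 1 to compound 2 (0.22 log units; within the scatter). Compound 3 `C/C(=C\c1cc(-c2ccc(C)cc2)cs1)C(N)=O` carries a different core; how the two cores differ is not broken down here. In this assay compound 3 reaches only a limit, > 50000 nM. Compound 4 `C/C(=C\c1cc(-c2ccc(F)cc2)cs1)C(N)=O`, not yet measured, differs from compound 3 by fluoro in place of methyl on an aromatic carbon, the same change as from compound 1 to compound 2. Beside that earlier step, the step from compound 3 to compound 4 is expected to be a step that the limit leaves unreadable from compound 3 to compound 4, because the same change gave a 1.7-fold lower number from compound 1 to compound 2 (0.22 log units; within the scatter) and because compound 3 sits at the limit of > 50000 nM in this assay, at which 1 of the 3 values shown sits. Compound 4 is therefore expected to give about 60000 nM, within 20000 nM to 200000 nM, most likely again as a limit.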

Compound 4, half-maximal inhibitory concentration: > 50000 nM
Compound 4: a limit, no number; the forecaster's own chance of this, stated with the estimate: 75%; the middle value is on the limit's open side.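

Compound 3 and compound 4 both end at a limit and not at a number, so no step between them can be read: the limit of > 50000 nM in this assay, at which 2 of the 4 values shown sit.

The compounds shown leave open what fluoro in place of methyl does on the core of compound 3.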